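Swapping the Aromatic Arm on a Shared Amine Core

The source may hold more compounds than are shown below. What is called first, only, known or untested is meant among the compounds shown, and "the series" means these compounds.

Three compounds share one core and differ in the aromatic group carried on a saturated chain carbon bound to an amine nitrogen. Compound 1 `Cc1ccc(CN[C@@H]2C[C@H]3C[C@@H]([C@H]2C)C3(C)C)s1` gives 780 nM in an ADME assay on MDCK cells (Canis lupus familiaris) for cytotoxicity, read by microscopy, with a stated time of 48 h; a higher number here means that more compound is tolerated, a lower number that less compound is tolerated. Compound 2 `C[C@H]1[C@H](NCc2sccc2C2CC2)C[C@H]2C[C@@H]1C2(C)C` gives 25000 nM in this assay, and compound 3 `C=Cc1csc(CN[C@@H]2C[C@H]3C[C@@H]([C@H]2C)C3(C)C)c1` gives 6250 nM. Among the three, compound 1 stands lowest; its nearest neighbour is compound 3, and the gap to both compound 3 and compound 2 lies beyond the scatter, so compound 1 is the least tolerated of the measured set.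

Compound 4 `Cc1n[nH]cc1CN[C@@H]1C[C@H]2C[C@@H]([C@H]1C)C2(C)C` has not yet been measured. It differs from compound 1 in one place: 3-methyl-1H-pyrazol-4-yl in place of 5-methylthiophen-2-yl on a saturated chain carbon bound to an amine nitrogen.

For the measured compounds named here, no measured pair follows this exact change, so the expected step rests only on the position of compound 1. Since compound 1 sits lowest and both other aromatic arms gave higher numbers, an upward step from compound 1 to compound 4, a 3.2-fold higher number from compound 1 to compound 4 (0.51 log units; beyond the scatter), is expected, though a result within the scatter cannot be excluded. Compound 4 is therefore estimated at 2500 nM, with a range from 600 nM to 12000 nM.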

Compound 4, minimum cytotoxic concentration: > 100000 nM
Compound 4: only a limit was reported; the forecaster's own chance of this, stated with the estimate: 10%; middle value at least 40-fold (1.60 log units) away from the limit.
By their numbers in this assay, from the lowest: compound 1; then compound 3; then compound 2. At a limit, above all of these: compound 4.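

The earlier compounds shown here gave no step at this position, and this pair supplies the first: 3-methyl-1H-pyrazol-4-yl in place of 5-methylthiophen-2-yl on a saturated chain carbon bound to an amine nitrogen gives an at least 120-fold higher number from compound 1 to compound 4 (2.10 log units; beyond the scatter) in this assay. Both groups hold 6 heavy atoms and one five-membered aromatic ring, yet the step is large, so at this position the identity of the ring matters far more than its size. Compound 4 is reported only as a limit, so the full size of the step remains unknown: the limit of > 100000 nM in this assay, at which 1 of the 4 values shown sits.

The pair changes the ring atoms and the hydrogen-bond donor together, so it does not separate their contributions. Going by these compounds, whether a 1-methylpyrazol-4-yl or a furan-2-yl arm would also reach this limit remains open.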